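Bromo-to-nitro exchange on the sulfonyl ring of sulfonanilides

A few compounds are considered here, and "the series" means these few. Any claim that something is new, unique, unknown or untested is made for them only; others in the source may bear on it.

Values in an ADME assay:
compound 1 `O=S(=O)(Nc1ccccc1)c1cccc(Br)c1`: 8.25
compound 2 `O=[N+]([O-])c1cccc(S(=O)(=O)Nc2ccccc2)c1`: 7.5
compound 3 `O=[N+]([O-])c1cccc(NS(=O)(=O)c2ccc(Br)cc2)c1`: 7.42

Among the compounds with values here, the one counted change, (nitro in place of bromo on an aromatic carbon), gives a number 0.75 log units lower from compound 1 to compound 2 (beyond the scatter). The difference between the core of compound 1 and the core of compound 3 is not broken down here; compound 3 and compound 2 give values that lie within the scatter of each other.

Compound 4 `O=[N+]([O-])c1ccc(S(=O)(=O)Nc2cccc([N+](=O)[O-])c2)cc1` is not yet measured. It differs from compound 3 by nitro in place of bromo on an aromatic carbon, the same kind of change as from compound 1 to compound 2, though there the place is meta to a large group and here para to a large group. A step of similar size is expected, a number 0.72 log units lower from compound 3 to compound 4 (beyond the scatter), resting on a number 0.75 log units lower from compound 1 to compound 2 (beyond the scatter). Compound 4 is therefore estimated at 6.7, between 6.3 and 7.1.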

Compound 4, acid dissociation constant: 5.51
For compound 4 the middle estimate is 1.19 log units above the measured one; the measured number lies below the stated range.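

In this assay, nitro in place of bromo on an aromatic carbon gives a number 1.91 log units lower from compound 3 to compound 4 (beyond the scatter), so the direction of the step carries to the second core. Its size does not carry over: the same change on two cores in this assay, a number 0.75 log units lower (beyond the scatter) from compound 1 to compound 2 and a number 1.91 log units lower (beyond the scatter) from compound 3 to compound 4, 1.16 log units apart, beyond the scatter of two such steps

In the new step the change lies para to a large group, and the earlier step does not share that place, so these two steps cannot separate the part played by the core from that played by the place, and two cores give no general rule for the series.

On these data alone, it remains open how a nitrile or a carboxylic acid in place of bromo would behave on these two cores. Also open, as far as these compounds go, is whether the nitro step would keep its size at another place on the core of compound 3.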